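A few compounds are considered here, and "the series" means these few. Any claim that something is new, unique, unknown or untested is made for them only; others in the source may bear on it.

Of the compounds shown here, three built on the same core have been tested in an ADME assay on HepG2 2.2.15 cells (Homo sapiens) for cytotoxicity, read by MTT assay, with stated times of 48 h and 9 days; a lower number here means that less compound is tolerated, a higher number that more compound is tolerated. Compound 1 `COc1ccc(CNC(=O)/C=C/c2coc3cc(O)ccc3c2=O)cc1` gives 718000 nM. Compound 3 `Cc1ccc(CNC(=O)/C=C/c2coc3cc(O)ccc3c2=O)cc1` gives 501000 nM. Compound 2 `COc1ccc2c(=O)c(/C=C/C(=O)Nc3cc(C)ccc3C)coc2c1` gives 1100000 nM, the highest of the three numbers; the value of compound 1 sits within the scatter of that of compound 2, while the value of compound 3 lies beyond it, so compound 2 is tolerated at least as well as either of the others.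

Within the data shown here, only one pair among the measured compounds differs in a single place. The step of a 1.4-fold lower number from compound 1 to compound 3 (0.16 log units; within the scatter) rests on a methyl in place of a methoxy on an aromatic carbon, and it did not move the number beyond the scatter.

Compound 4 `COc1ccc2c(=O)c(/C=C/C(=O)Nc3ccc(C)cc3)coc2c1` differs from compound 2 in one place: 4-methylphenyl in place of 2,5-dimethylphenyl on an amide-type nitrogen. Like the measured step, this change trades one small carbon group for another on an aromatic part of the molecule, and the measured step stayed within the scatter. No larger movement is therefore expected here, in either direction. Compound 4 is expected to give 1000000 nM, with a range from 500000 nM to 2000000 nM. The estimated step of a 1.1-fold lower number from compound 2 to compound 4 (0.04 log units; within the scatter) is expected to stay within the scatter.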

Compound 4, half-maximal cytotoxic concentration: 979000 nM
Compound 4: the middle estimate sits 1.0-fold (0.01 log units) above what was measured; measured number inside the range.
By their numbers in this assay, from the lowest: compounds 3, 1, 4 and 2 (each within the scatter of the next, the first and the last beyond it).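

In this assay, among these compounds, the step of a 1.1-fold lower number from compound 2 to compound 4 (0.05 log units; within the scatter) gives the first reading for a change on the amide-type nitrogen, since the earlier single-place step concerned methyl in place of methoxy on an aromatic carbon. Here 4-methylphenyl stands in place of 2,5-dimethylphenyl, a swap between two carbon-only aromatic groups with the smaller one entering, and the step stays within the scatter, so this assay does not tell these two groups apart on this nitrogen. No independent information on this pair bears on the result, so it stands as a plain observation, with nothing to account for it.

From the compounds shown here alone, both groups seen on this nitrogen are aromatic rings of carbon only, so it remains open whether a ring carrying a carboxylic acid or an amine, or a longer open carbon chain in place of the ring, would also stay within the scatter of compound 2. Going by these compounds, it also remains open whether 4-methylphenyl and 2,5-dimethylphenyl would read alike on the core of compound 1, which differs from that of compound 2.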